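This account rests on a few compounds, and the source may have more. Where it says the series, first, only, none or still open, it means among the compounds named here.

Measured so far in an assay on HEK293 cells for displacement of a labelled ligand from C-C chemokine receptor type 4 (Homo sapiens); a lower number here means a stronger inhibitor, a higher number a weaker inhibitor:
Compound 1 `CN1CCCC(C(=O)NCCNc2nccc(OCc3ccc(Cl)cc3Cl)n2)C1` gives > 10000 nM, which is a limit of the assay and not a number.
Compound 2 `CC(C)[C@@H](CNc1nccc(OCc2ccc(Cl)cc2Cl)n1)NC(=O)C1CCCN(C)C1` gives 5600 nM.
Compound 3 `O=C(C1CCNCC1)N1CCN(c2nccc(NCc3ccc(Cl)cc3Cl)n2)CC1` gives > 10000 nM, again a limit of the assay.

Compound 3 therefore stands at the weak end of what this assay reports, with no number of its own, and compound 1 sits at that same limit (the limit of > 10000 nM in this assay, at which 2 of the 3 values shown sit). Compound 4 `O=C(C1CCCNC1)N1CCN(c2nccc(NCc3ccc(Cl)cc3Cl)n2)CC1` keeps every atom of compound 3 and changes only where the saturated ring attaches to the carbonyl: piperidin-3-yl in place of piperidin-4-yl on a carbonyl carbon. Among the measured compounds shown here, the only measured step, an at least 1.7-fold lower number from compound 1 to compound 2 (0.25 log units; that floor lies within the scatter), concerns a different kind of change in a different part of the shared core, and its floor lies within the scatter; no measured step moves the attachment point of a ring, so nothing measured bears directly on this change. With compound 3 already at the limit, compound 4 is expected to remain close to it, a step that the limit leaves unreadable from compound 3 to compound 4 being no more than the scatter and in no definite direction. Compound 4 is estimated at 12000 nM in this assay, with a likely range from 3000 nM to 50000 nM.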

Compound 4, half-maximal inhibitory concentration: 800 nM
Compound 4: the middle estimate sits 15-fold (1.18 log units) above what was measured; measured number outside the range, below it.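

With the same atoms joined differently, piperidin-3-yl in place of piperidin-4-yl on a carbonyl carbon gives an at least 12-fold lower number from compound 3 to compound 4 (1.09 log units; beyond the scatter), so in this assay the point where this saturated ring attaches to the carbonyl matters a great deal. Among the compounds shown here, the only earlier readable step, an at least 1.7-fold lower number from compound 1 to compound 2 (0.25 log units; that floor lies within the scatter), gave no such clear signal, and no earlier pair tested a move of this kind. The full size of the new step remains unknown because compound 3 has only a limit and no number of its own: the limit of > 10000 nM in this assay, at which 2 of the 4 values shown sit.

As far as these compounds go, it remains open whether the gain needs the ring nitrogen, which a cyclohexyl group on the same carbonyl carbon would test. A piperidin-2-yl or pyrrolidin-3-yl group there could show whether the gain extends to other attachment points or ring sizes.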